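Extending an Alkoxy Chain on a Bile Acid Receptor Agonist

A few compounds are considered here, and "the series" means these few. Any claim that something is new, unique, unknown or untested is made for them only; others in the source may bear on it.

Measured in a functional assay for agonist activity at Bile acid receptor (Homo sapiens), read by FRET; a lower number here means that less compound is needed, a higher number that more compound is needed for the effect:
Compound 1 `CCc1cc(C(=O)O)nc2ccc(-c3ccc(OCc4c(-c5c(Cl)cccc5Cl)noc4C(C)C)cc3)cc12`: 75 nM
Compound 2 `COc1cc(C(=O)O)nc2ccc(-c3ccc(OCc4c(-c5c(Cl)cccc5Cl)noc4C(C)C)cc3)cc12`: 58 nM
Compound 3 `CCOc1cc(C(=O)O)nc2ccc(-c3ccc(OCc4c(-c5c(Cl)cccc5Cl)noc4C(C)C)cc3)cc12`: 52 nM

Compound 3 has the lowest number of the three, but its distance to the others is within the scatter: a 1.4-fold lower number from compound 1 to compound 3 (0.16 log units; within the scatter) and a 1.1-fold lower number from compound 2 to compound 3 (0.05 log units; within the scatter). Compound 4 `CC(C)Oc1cc(C(=O)O)nc2ccc(-c3ccc(OCc4c(-c5c(Cl)cccc5Cl)noc4C(C)C)cc3)cc12` differs from compound 3 by methyl in place of hydrogen on a saturated chain carbon bound to an oxygen on an aromatic ring and a saturated chain carbon. Among the measured compounds shown here, the only comparable step is the one from compound 2 to compound 3, where the same kind of lengthening gave a 1.1-fold lower number from compound 2 to compound 3 (0.05 log units; within the scatter). On that basis no step beyond the scatter is expected in this assay, and the expected change a 1.0-fold lower number from compound 3 to compound 4 (0.02 log units; within the scatter) is small. Compound 4 is therefore estimated at 50 nM, with a range from 25 nM to 100 nM.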

Compound 4, half-maximal effective concentration: 40 nM
For compound 4 the middle estimate is 1.3-fold (0.10 log units) above the measured one; the range from low to high includes it.
By their numbers in this assay, from the lowest: compounds 4, 3, 2 and 1 (each within the scatter of the next).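

In this assay the added methyl that turns ethoxy into isopropoxy gives a 1.3-fold lower number from compound 3 to compound 4 (0.11 log units; within the scatter) so a branched group on this oxygen keeps the number in the same range as the unbranched ethoxy. Among the compounds shown here, the wider comparisons also stay inside the scatter, with a 1.5-fold lower number from compound 2 to compound 4 (0.16 log units; within the scatter) and a 1.9-fold lower number from compound 1 to compound 4 (0.27 log units; within the scatter) so no reliable step separates any of the four compounds. No available evidence bears on a reason for this tolerance. Still open, on these data alone, is whether a longer chain such as butoxy, a cyclohexyloxy group or an amine at this position would move the number beyond the scatter.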